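The compounds below may be only part of what the source reports. "The series", "measured", "known", "first", "only" and "open" are said of these compounds alone.

Measured in a functional assay on MDA-MB-231 cells (Homo sapiens) for cytotoxicity, read by MTT assay, with a stated time of 72 h; on this read-out higher numbers stand for weaker inhibition and lower numbers for stronger inhibition:
compound 1 `CN(C)CCCNc1nc(-c2ccc(NC(=O)Nc3ccc(Cl)cc3)cc2)nc2c(Cl)c(Cl)sc12`: 1160 nM
compound 2 `CN(C)CCCNc1nc(-c2ccc(NC(=O)Nc3ccccc3Cl)cc2)nc2c(Cl)c(Cl)sc12`: 1560 nM
compound 3 `CCN(CC)CCCNc1nc(-c2ccc(NC(=O)Nc3ccc(Cl)cc3)cc2)nc2c(Cl)c(Cl)sc12`: 660 nM

Compound 4 `CCN(CC)CCCNc1nc(-c2ccc(NC(=O)Nc3ccccc3Cl)cc2)nc2c(Cl)c(Cl)sc12` is not yet measured in this assay. It differs from compound 3 by 2-chlorophenyl in place of 4-chlorophenyl on an amide-type nitrogen. The same change occurs once among the measured compounds, as 2-chlorophenyl in place of 4-chlorophenyl on an amide-type nitrogen, and there it gave a 1.3-fold higher number from compound 1 to compound 2 (0.13 log units; within the scatter). The cores of the two pairs differ only by diethylamino in place of dimethylamino on a saturated chain carbon, three bonds along the chain from a nitrogen on an aromatic ring, a change that gave a 1.8-fold lower number from compound 1 to compound 3 (0.24 log units; within the scatter). In this assay compound 3 has the lowest of the three numbers, though its gap to compound 1 is within the scatter, so no order is claimed between them.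

For compound 4 a step of about a 1.3-fold higher number from compound 3 to compound 4 (0.11 log units; within the scatter) is expected, resting on the earlier step of a 1.3-fold higher number from compound 1 to compound 2 (0.13 log units; within the scatter) in the other pair. Compound 4 is therefore expected to give about 860 nM, with a likely range from 480 nM to 1550 nM.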

Compound 4, half-maximal inhibitory concentration: 970 nM
Beside the measured number, compound 4's estimate is 1.1-fold (0.05 log units) below it, within the range that was stated.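

In this assay, 2-chlorophenyl in place of 4-chlorophenyl gives a 1.5-fold higher number from compound 3 to compound 4 (0.17 log units; within the scatter), in agreement with the same change on the core of compound 1: the same change on two cores in this assay, a 1.3-fold higher number (0.13 log units; within the scatter) from compound 1 to compound 2 and a 1.5-fold higher number (0.17 log units; within the scatter) from compound 3 to compound 4, 1.1-fold (0.04 log units) apart, within the scatter of two such steps. Diethylamino in place of dimethylamino gives a 1.6-fold lower number from compound 2 to compound 4 (0.21 log units; within the scatter), and this also agrees with the earlier step: the same change on two cores in this assay, a 1.8-fold lower number (0.24 log units; within the scatter) from compound 1 to compound 3 and a 1.6-fold lower number (0.21 log units; within the scatter) from compound 2 to compound 4, 1.1-fold (0.04 log units) apart, within the scatter of two such steps. These four steps show no sign that either change depends on the core across these two pairs, but each lies within the scatter, so they show neither a real effect of either change nor how it would carry to other cores.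

The compounds shown leave open whether a larger change at either site would give a step beyond the scatter. Candidates are an unsubstituted phenyl on the amide-type nitrogen, a morpholine in place of the diethylamino group, or a longer chain.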